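Compound 1 to compound 4: an amide-nitrogen swap

The compounds below may be only part of what the source reports. "The series", "measured", "known", "first", "only" and "open" are said of these compounds alone.

Compound 1 `Cc1ccc(NC(=O)CSc2nc3ccccc3n2S(=O)(=O)c2cc(C)cc(C)c2)cc1`: 2970 nM
Compound 2 `COC(=O)c1ccc(NC(=O)COc2nc3ccccc3n2S(=O)(=O)c2cc(C)cc(C)c2)c(Cl)c1`: 119000 nM
Compound 3 `Cc1cc(C)cc(S(=O)(=O)n2c(OCC(=O)Nc3ccc(S(C)(=O)=O)cc3Cl)nc3ccccc32)c1`: > 228000 nM (a limit)

In an ADME assay on MT4 cells (Homo sapiens) for cytotoxicity, read by MTT assay, with a stated time of 5 days (a higher number here means that more compound is tolerated, a lower number that less compound is tolerated), compound 1 gives 2970 nM, the lower of the two numbers, and compound 2 stands far higher at 119000 nM. Compound 4 `Cc1cc(C)cc(S(=O)(=O)n2c(SCC(=O)Nc3ccccc3Cl)nc3ccccc32)c1` differs from compound 1 in one place: 2-chlorophenyl in place of 4-methylphenyl on an amide-type nitrogen. Among the compounds with values here, no measured step covers this change. The only one, an at least 1.9-fold higher number from compound 2 to compound 3 (0.28 log units; that floor lies within the scatter), exchanges other groups. Compound 3 sits at a limit, (the limit of > 228000 nM in this assay, at which 1 of the 3 values shown sits). That step therefore offers no size to carry over, and the expectation rests on compound 1 at 2970 nM. The expected change stays within the scatter: a 1.5-fold higher number from compound 1 to compound 4 (0.18 log units; within the scatter). Compound 4 is estimated at 4500 nM, with an expected range of 1300 nM to 20000 nM.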

Compound 4, half-maximal cytotoxic concentration: 107000 nM
Compound 4: middle estimate off by 24-fold (1.38 log units), on the low side, outside the stated range (above it).
By their numbers in this assay, from the lowest: compound 1; then compounds 4 and 2 (each within the scatter of the next). At a limit, above all of these: compound 3.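

In this assay the group on the amide-type nitrogen proves to matter: a 36-fold higher number from compound 1 to compound 4 (1.56 log units; beyond the scatter), with 2-chlorophenyl in place of 4-methylphenyl and the rest of compound 1 unchanged. This is the first step shown with a readable size, and it comes from a swap that leaves the heavy-atom count of the group the same. Nothing at hand accounts for the size of this step.

Still open, going by these compounds, is whether the step belongs to the chlorine, to the loss of the methyl, or to both. On these data alone, how an amine or a carboxylic acid on that phenyl ring would read also remains open.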